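The compounds below may be only part of what the source reports. "The series", "measured", "known", "first", "only" and "open" are said of these compounds alone.

Compound 2 `Cc1cc(Nc2cccc(Cl)c2)c(S(C)(=O)=O)cc1C(=O)N=C(N)N` gives 33 nM in a functional assay for inhibition of sodium/hydrogen exchanger (Oryctolagus cuniculus) (on this read-out higher numbers stand for weaker inhibition and lower numbers for stronger inhibition), and stands highest of the two numbers shown; compound 1 `Cc1cc(-n2ccnc2C)c(S(C)(=O)=O)cc1C(=O)N=C(N)N` gives 29 nM in this assay, a gap that lies within the scatter. Within the data shown here, the only measured step, a 1.1-fold higher number from compound 1 to compound 2 (0.06 log units; within the scatter), replaced the group on the same aromatic carbon and moved the number very little. Compound 3 `Cc1cc(Oc2cncc(Cl)c2)c(S(C)(=O)=O)cc1C(=O)N=C(N)N` carries (5-chloropyridin-3-yl)oxy in place of (3-chlorophenyl)amino on an aromatic carbon. Among the measured compounds shown here, no measured step covers an aryloxy group here, so no shift beyond the scatter is expected. Compound 3 is therefore estimated at 40 nM in this assay, with a range of 15 nM to 110 nM. The expected step is a 1.2-fold higher number from compound 2 to compound 3 (0.08 log units; within the scatter).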

Compound 3, half-maximal inhibitory concentration: 14 nM
Beside the measured number, compound 3's estimate is 2.9-fold (0.46 log units) above it; measured number outside the range, below it.
By their numbers in this assay, from the lowest: compound 3; then compounds 1 and 2 (each within the scatter of the next).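

On the shared core, the carbon ortho to a methylsulfonyl group had shown no movement in this assay, but (5-chloropyridin-3-yl)oxy gives a 2.4-fold lower number from compound 2 to compound 3 (0.37 log units; beyond the scatter) and a 2.1-fold lower number from compound 1 to compound 3 (0.32 log units; beyond the scatter), so the number does respond to the group placed here. Both steps are modest, and compound 3 has the lowest number of the three. Nothing measured on these compounds accounts for the shift.

Going by these compounds, the step from compound 2 to compound 3 swaps the linking atom and the ring together, so the share of each stays open; (3-chlorophenyl)oxy or (5-chloropyridin-3-yl)amino would separate them. Also open, on these data alone, is how a non-aromatic amine such as morpholine would read at this carbon.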